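Trading a Ring for a Chain on the Amide Side

This account rests on a few compounds, and the source may have more. Where it says the series, first, only, none or still open, it means among the compounds named here.

Compound 2 `CCC(NC(=O)C(CC(C)C)NC(=O)OCc1ccccc1)C(=O)C(=O)NCC1CCCCC1` gives 44 nM in an assay on isolated protein (Oryctolagus cuniculus) for inhibition of Calpain-2 catalytic subunit (Homo sapiens), at pH 8.0 (on this read-out higher numbers stand for weaker inhibition and lower numbers for stronger inhibition), the lower of the two measured numbers; compound 1 `CCOC(=O)C(=O)C(CC)NC(=O)C(CC(C)C)NS(=O)(=O)c1ccc2ccccc2c1` gives 2200 nM, a gap well beyond the usual scatter. Compound 3 `CCCCCCCCCCNC(=O)C(=O)C(CC)NC(=O)C(CC(C)C)NC(=O)OCc1ccccc1` keeps everything of compound 2 except one change: nonyl in place of cyclohexyl on a saturated chain carbon bound to an amide-type nitrogen. Among the compounds with values here, no measured pair shows this kind of ring-to-chain swap, so its effect has to be guessed. Compound 3 is expected to land close to compound 2, with a step of a 1.4-fold higher number from compound 2 to compound 3 (0.13 log units; within the scatter) that may stay within the scatter. The estimate for compound 3 is 60 nM, in a range from 15 nM to 250 nM.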

Compound 3, inhibition constant: 600 nM
For compound 3 the middle estimate is 10-fold (1.00 log units) below the measured one; the whole stated range lies below it.
By their numbers in this assay, from the lowest: compound 2; then compound 3; then compound 1.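

This position does not treat all carbon groups alike: nonyl in place of cyclohexyl gives a 14-fold higher number from compound 2 to compound 3 (1.13 log units; beyond the scatter) and so costs far more than the usual scatter, although neither group carries hydrogen-bond donors, acceptors or a net charge. The change removes the ring and adds carbon atoms at once, so the two effects cannot be told apart. Nothing at hand explains the step. On these data alone, whether a shorter chain such as butyl would do better remains open. So does the effect of an amine or a carboxylic acid at the end of the chain.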